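Notes on the amide substituent in a two-compound series

This account rests on a few compounds, and the source may have more. Where it says the series, first, only, none or still open, it means among the compounds named here.

Two compounds carry measured numbers in an assay on THP-1 cells for displacement of a labelled ligand from C-C chemokine receptor type 1 (Homo sapiens); on this read-out lower numbers stand for stronger inhibition and higher numbers for weaker inhibition. Compound 1 `CC(C)C(NS(=O)(=O)Cc1ccccc1)C(=O)N1CCC(c2ccc(Cl)cc2)CC1` gives 303 nM. Compound 2 `CC(C)[C@@H](NC(=O)CCc1ccc(F)cc1)C(=O)N1CCC(c2ccc(Cl)cc2)CC1` gives 70 nM, the lowest of the two numbers; since these two compounds differ in more than one place, their values are taken as they stand, with compound 1 at the higher number, beyond the scatter. Compound 3 `CC(C)[C@@H](NC(=O)c1cc2ccccc2s1)C(=O)N1CCC(c2ccc(Cl)cc2)CC1` has not been measured. It differs from compound 2 in one place: 1-benzothiophen-2-yl in place of 2-(4-fluorophenyl)ethyl on a carbonyl carbon. Going by the values given here, no step between measured compounds isolates a change of this kind, so the expectation rests on the value of compound 2 alone. For compound 3 a small step towards a higher number in this assay is expected, a 2.1-fold higher number from compound 2 to compound 3 (0.33 log units; beyond the scatter), which may well stay within the scatter. The estimate for compound 3 in this assay is 150 nM, with a range from 40 nM to 600 nM.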

Compound 3, half-maximal inhibitory concentration: 58 nM
For compound 3 the middle estimate is 2.6-fold (0.41 log units) above the measured one; the range from low to high includes it.
By their numbers in this assay, from the lowest: compounds 3 and 2 (each within the scatter of the next); then compound 1.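

In this assay, going by these compounds alone, the exchange of 2-(4-fluorophenyl)ethyl for 1-benzothiophen-2-yl on a carbonyl carbon gives a 1.2-fold lower number from compound 2 to compound 3 (0.08 log units; within the scatter) and is the first step that can be read at this position. The position therefore holds two differently built groups of equal heavy-atom count, one with a single six-membered aromatic ring of carbon only and the other with a five-membered aromatic ring carrying a hetero atom as well, and the read-out stays within the scatter. No measurement on hand speaks to why these two groups read alike.

Going by these compounds, how this position responds to an amine or a carboxylic acid on the substituent remains open. On these data alone, a longer chain carrying the 4-fluorophenyl ring also remains open, as does a simple phenyl directly on the carbonyl carbon.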